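One Number Beside Two Limits

This account rests on a few compounds, and the source may have more. Where it says the series, first, only, none or still open, it means among the compounds named here.

Three esters sharing one core have been tested in a functional assay on A549 cells (Homo sapiens) for antiproliferative activity, read by MTT assay, with a stated time of 48 h; a higher number here means a weaker inhibitor, a lower number a stronger inhibitor. Compound 1 `C/C(=C\CC/C(C)=C/CC[C@@H]1[C@@]2(C)CCC(=O)C(C)(C)[C@H]2CC[C@@]1(C)O)CC/C=C(\C)C(=O)OCc1cn(-c2ccccc2C(F)(F)F)nn1` gives only a limit, > 150000 nM. Compound 2 `COc1ccc(-n2cc(COC(=O)/C(C)=C/CC/C(C)=C/CC/C(C)=C/CC[C@@H]3[C@@]4(C)CCC(=O)C(C)(C)[C@H]4CC[C@@]3(C)O)nn2)cc1` also gives only a limit, > 150000 nM. Among the compounds with values here, compound 3 `C/C(=C\CC/C(C)=C/CC[C@@H]1[C@@]2(C)CCC(=O)C(C)(C)[C@H]2CC[C@@]1(C)O)CC/C=C(\C)C(=O)OCc1cn(-c2cccc(F)c2)nn1` gives 124000 nM, the only true number of the three. The series therefore stands against (the limit of > 150000 nM in this assay, at which 2 of the 3 values shown sit).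

Compound 4 `C/C(=C\CC/C(C)=C/CC[C@@H]1[C@@]2(C)CCC(=O)C(C)(C)[C@H]2CC[C@@]1(C)O)CC/C=C(\C)C(=O)OCc1cn(-c2ccc(C)cc2)nn1` differs from compound 3 by one swap, 4-methylphenyl in place of 3-fluorophenyl on an aromatic nitrogen.

The measured steps that bear on this swap change the same group. They are an at least 1.2-fold lower number from compound 1 to compound 3 (0.08 log units; that floor lies within the scatter) and an at least 1.2-fold lower number from compound 2 to compound 3 (0.08 log units; that floor lies within the scatter), and each is only a floor within the scatter. The remaining step, a step that the two limits leave unreadable from compound 1 to compound 2, gives no size at all. Nothing here points to a real change, so no step beyond the scatter is expected in this assay, and compound 4 may return only a limit. The expected step is a 1.1-fold higher number from compound 3 to compound 4 (0.05 log units; within the scatter). For compound 4 the estimated value is 140000 nM, with an expected range of 75000 nM to 220000 nM.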

Compound 4, half-maximal inhibitory concentration: > 150000 nM
Compound 4 gave a limit, no number (the forecaster's own chance of this, stated with the estimate: 45%); middle value at least 1.0-fold (0.02 log units) away from the limit.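

Swapping 3-fluorophenyl for 4-methylphenyl on the aromatic nitrogen gives, in this assay, an at least 1.2-fold higher number from compound 3 to compound 4 (0.08 log units; that floor lies within the scatter), so this change shows no real effect on the number. Compound 4 returns only a limit, and the steps that join it to compound 1 and compound 2 link one limit to another and cannot be read. A fourth substituted phenyl at this position has now produced no step beyond the scatter, and most of the series rests at one ceiling: the limit of > 150000 nM in this assay, at which 3 of the 4 values shown sit.

The compounds shown leave open whether a different group on this nitrogen, such as a phenyl ring carrying an amine or a carboxylic acid, would give a number clearly below that limit. They also cannot tell how far beyond its limit the true value of compound 4 lies.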